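Amide aryl exchange on the shared core: compound 2 to compound 3

This account rests on a few compounds, and the source may have more. Where it says the series, first, only, none or still open, it means among the compounds named here.

Of the compounds shown here, two have been measured in a functional assay on HEK293 cells for agonist activity at D(4) dopamine receptor (Homo sapiens), read by FLIPR (a higher number here means a larger maximal response, a lower number a smaller maximal response), so far. Compound 1 `Cc1cc(F)ccc1NC(=O)CN1CCC(c2cccc[n+]2[O-])CC1` gives 84%. Within the data shown here, compound 2 `CCc1cccc(NC(=O)CN2CCC(c3cccc[n+]3[O-])CC2)c1` gives 62%, the lowest of the two numbers, with compound 1 as its only neighbour. Among the measured compounds shown here, the single measured step is the exchange on the amide-type nitrogen, a number 22 percentage points lower from compound 1 to compound 2 (beyond the scatter), a modest fall beyond the scatter.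

Compound 3 `O=C(CN1CCC(c2cccc[n+]2[O-])CC1)Nc1ccccc1F` is not yet measured. It differs from compound 2 in one place: 2-fluorophenyl in place of 3-ethylphenyl on an amide-type nitrogen. The 3-ethylphenyl that entered in the step from compound 1 to compound 2 leaves again here, and a fluorine-bearing aryl group comes in, which in make-up sits nearer to the 4-fluoro-2-methylphenyl of compound 1 than to the 3-ethylphenyl of compound 2.

For the measured compounds named here, only the step from compound 1 to compound 2 bears on this change, and only in part, since the group that enters is neither of the two already seen. Its removal of the 3-ethylphenyl argues for a partial return towards compound 1. For compound 3 a modest rise is therefore expected, a number 12 percentage points higher from compound 2 to compound 3 (beyond the scatter). Compound 3 is estimated at 74%, within 56% to 92%.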

Compound 3, largest response reached (reported as efficacy), in percent of the reference or control that the assay uses: 63%
Compound 3: middle estimate off by 11 percentage points, on the high side; measured number inside the range.
By their numbers in this assay, from the lowest: compounds 2 and 3 (each within the scatter of the next); then compound 1.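

Working notes on the amide aryl group. In this assay, the exchange of 3-ethylphenyl for 2-fluorophenyl on the amide-type nitrogen gives a number 1 percentage points higher from compound 2 to compound 3 (within the scatter) and so does not separate these two aryl groups, although they differ in make-up. The other comparison, a number 21 percentage points lower from compound 1 to compound 3 (beyond the scatter) for 2-fluorophenyl in place of 4-fluoro-2-methylphenyl, shows that a fluorine on the aryl group is not enough by itself to reach the level of compound 1, and among the three compounds only the 4-fluoro-2-methylphenyl stands apart from the others. No measurement at hand accounts for the distance between the 4-fluoro-2-methylphenyl and the other two aryl groups.

The compounds shown leave open whether the higher response of compound 1 goes with its methyl, with its fluorine, or with the two together, a question that a plain methylphenyl or fluorophenyl on the amide-type nitrogen would address. Also open, on these data alone, is how an unsubstituted phenyl, a chlorine or a methoxy on this aryl group would compare on the shared core.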